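The source may report more compounds than this note shows. Statements on the series, on what has been measured and on what is new or still open speak of the compounds shown alone.

Compound 1 `CCn1nc(CC(=O)Nc2ccc(OC(F)(F)F)c(Cl)c2)c2ccccc2c1=O` gives 199 nM in a functional assay on CHO cells for antagonist activity at sphingosine 1-phosphate receptor 2 (Homo sapiens), read by calcium flux; a lower number here means a stronger inhibitor, a higher number a weaker inhibitor.
Compound 2 `O=C(Cc1nn(CC(=O)N2CCOCC2)c(=O)c2ccccc12)Nc1ccc(OC(F)(F)F)c(Cl)c1` gives 30 nM in this assay.

Among the compounds with values here, compound 2 holds the lower of the two numbers; the one step measured, a 6.6-fold lower number from compound 1 to compound 2 (0.82 log units; beyond the scatter), lies beyond the scatter. Compound 3 `O=C(O)Cn1nc(CC(=O)Nc2ccc(OC(F)(F)F)c(Cl)c2)c2ccccc2c1=O` differs from compound 2 by hydroxy in place of morpholin-4-yl on a carbonyl carbon. Within the data shown here, only that one step touches the same chain carbon, and it concerned a different group, so it gives just a rough guide. The hydroxy is expected to cost some of the gain seen with the morpholin-4-yl, a step of about a 3.3-fold higher number from compound 2 to compound 3 (0.52 log units; beyond the scatter). Compound 3 is therefore estimated at 100 nM, within 25 nM to 400 nM.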

Compound 3, half-maximal inhibitory concentration: 389 nM
The estimate for compound 3 lay 3.9-fold (0.59 log units) below the measured number, and the stated range covers the measured number.
By their numbers in this assay, from the lowest: compound 2; then compounds 1 and 3 (each within the scatter of the next).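

On the carbonyl carbon, hydroxy in place of morpholin-4-yl gives a 13-fold higher number from compound 2 to compound 3 (1.11 log units; beyond the scatter) in this assay, so the gain seen with compound 2 does not come with the carbonyl alone. Carboxy in place of methyl on the saturated chain carbon gives a 2.0-fold higher number from compound 1 to compound 3 (0.29 log units; within the scatter), so these two groups do not separate here. Nothing at hand accounts for either step.

From the compounds shown here alone, whether the gain needs morpholin-4-yl itself or any tertiary amide remains open, and a piperidin-1-yl or dimethylamino amide would bear on this. Going by these compounds, the effect of a longer chain before the carbonyl also remains open.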